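Aryl change on the weaker measured compound

The source may report more compounds than this note shows. Statements on the series, on what has been measured and on what is new or still open speak of the compounds shown alone.

- compound 1 `COc1ccc(/C=C(/Sc2ccc(C)cc2)C(=O)c2ccc(Cl)cc2)cc1O`: 1000 nM
- compound 2 `Cc1ccc(S/C(=C/c2cc(C)cc(C)c2)C(=O)c2ccc(Cl)cc2)cc1`: 50000 nM

In a functional assay on DU-145 cells (Homo sapiens) for inhibition, read by trypan blue exclusion, with a stated time of 96 h (on this read-out higher numbers stand for weaker inhibition of growth and lower numbers for stronger inhibition of growth), compound 2 gives 50000 nM, the higher of the two numbers. Compound 3 `Cc1ccc(S/C(=C/c2ccc(Cl)cc2)C(=O)c2ccc(Cl)cc2)cc1` differs from it as follows: 4-chlorophenyl in place of 3,5-dimethylphenyl on a double-bonded chain carbon bound to a double-bonded chain carbon. Within the data shown here, the only measured step at this place is a 50-fold higher number from compound 1 to compound 2 (1.70 log units; beyond the scatter), a large one that removed 3-hydroxy-4-methoxyphenyl. Compound 3 also lacks that group, so it is expected to stay close to compound 2. Among the measured compounds shown here, no measured step shows this exchange itself. The expected step is a 2.0-fold lower number from compound 2 to compound 3 (0.30 log units; within the scatter), small and toward a lower number. Compound 3 is estimated at 25000 nM, with an expected range of 6000 nM to 80000 nM.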

Compound 3, concentration for 50% growth inhibition: 10000 nM
Beside the measured number, compound 3's estimate is 2.5-fold (0.40 log units) above it; low and high end bracket the measured number.
By their numbers in this assay, from the lowest: compound 1; then compound 3; then compound 2.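

On the double-bonded chain carbon, the aryl groups lacking 3-hydroxy-4-methoxyphenyl are not interchangeable: 4-chlorophenyl in place of 3,5-dimethylphenyl gives a 5.0-fold lower number from compound 2 to compound 3 (0.70 log units; beyond the scatter) and recovers part of the earlier loss. The recovery is incomplete, with a 10-fold higher number from compound 1 to compound 3 (1.00 log units; beyond the scatter) on replacing 3-hydroxy-4-methoxyphenyl with 4-chlorophenyl, and compound 1 keeps the lowest number of the three. Nothing on hand accounts for either step.

As far as these compounds go, it remains open which part of 3-hydroxy-4-methoxyphenyl goes with the lower number. Also open, from the compounds shown here alone, is whether 3-hydroxyphenyl, 4-methoxyphenyl or 4-aminophenyl would fall nearer compound 1 or compound 3.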